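A few compounds are considered here, and "the series" means these few. Any claim that something is new, unique, unknown or untested is made for them only; others in the source may bear on it.

Compound 1 `CCOc1ccc(NC2=CC(=O)c3ncsc3C2=O)cc1`: in a functional assay on HepG2 cells (Homo sapiens) for cytotoxicity, read by MTT assay (on this read-out lower numbers stand for stronger inhibition and higher numbers for weaker inhibition), compound 1 gives 23.6 ug/mL.
Compound 2 `O=C1C=C(Nc2ccc(OC(F)(F)F)cc2)C(=O)c2scnc21`: in this assay compound 2 gives only a limit, > 100 ug/mL.

Compound 2 therefore stands at the limit of this assay (the limit of > 100 ug/mL in this assay, at which 1 of the 2 values shown sits), and no number is known for it. Compound 3 `O=C1C=C(Nc2ccc(Cl)cc2)C(=O)c2scnc21` differs from compound 2 by chloro in place of trifluoromethoxy on an aromatic carbon. For the measured compounds named here, no measured step covers this exchange. Going by the values given here, the only measured step, an at least 4.2-fold higher number from compound 1 to compound 2 (0.62 log units; beyond the scatter), concerns a different group at the same position and shows that this position can move the number beyond the scatter. For compound 3 a number short of the limit is expected, which would mean an at least 2.0-fold lower number from compound 2 to compound 3 (0.30 log units; that floor lies within the scatter). The estimate for compound 3 is 50 ug/mL, within 15 ug/mL to 120 ug/mL.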

Compound 3, half-maximal inhibitory concentration: 16.4 ug/mL
Beside the measured number, compound 3's estimate is 3.0-fold (0.48 log units) above it, and the stated range covers the measured number.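

With chloro in place of trifluoromethoxy on this aromatic carbon, this assay gives a readable number again, with an at least 6.0-fold lower number from compound 2 to compound 3 (0.78 log units; beyond the scatter). Chloro and ethoxy read alike here, with a 1.4-fold lower number from compound 1 to compound 3 (0.16 log units; within the scatter), so among the three groups only trifluoromethoxy stands apart. The value of compound 2 is a limit and not a number, so the full size of its step stays unknown: the limit of > 100 ug/mL in this assay, at which 1 of the 3 values shown sits.

The compounds shown leave open how an amine or a carboxylic acid on this carbon would read. Going by these compounds, whether any group other than trifluoromethoxy also reaches the limit remains open too.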